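Chloro in Place of Fluoro in a Second Pair

This account rests on a few compounds, and the source may have more. Where it says the series, first, only, none or still open, it means among the compounds named here.

Measured in a functional assay on MCF7 cells (Homo sapiens) for antiproliferative activity, read by MTT assay, with a stated time of 48 h, in the presence of a further agent that is not named here; a lower number here means a stronger inhibitor of growth, a higher number a weaker inhibitor of growth:
compound 1 `Cc1ccc(-c2nn(-c3ccccc3)cc2C(=O)NOCc2ccccc2F)cc1` — 2110 nM
compound 2 `Cc1ccc(-c2nn(-c3ccccc3)cc2C(=O)NOCc2ccccc2Cl)cc1` — 2640 nM
compound 3 `O=C(NOCc1ccccc1F)c1cn(-c2ccccc2)nc1-c1ccc(Cl)cc1` — 15100 nM

Compound 2 differs from compound 1 by chloro in place of fluoro on an aromatic carbon, and this gave a 1.3-fold higher number from compound 1 to compound 2 (0.10 log units; within the scatter). The core of compound 3 differs from that of compound 1 by chloro in place of methyl on an aromatic carbon, which gave a 7.2-fold higher number from compound 1 to compound 3 (0.85 log units; beyond the scatter); compound 3 has the highest number of the three.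

Compound 4 `O=C(NOCc1ccccc1Cl)c1cn(-c2ccccc2)nc1-c1ccc(Cl)cc1` has not yet been measured. It differs from compound 3 by chloro in place of fluoro on an aromatic carbon, the same change as between compound 1 and compound 2, at the same place. Compound 4 is therefore expected to stay close to compound 3 in this assay, with an estimated 1.2-fold higher number from compound 3 to compound 4 (0.08 log units; within the scatter), because a 1.3-fold higher number from compound 1 to compound 2 (0.10 log units; within the scatter) lay within the scatter. The estimate for compound 4 is 18000 nM, expected between 9000 nM and 36000 nM.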

Compound 4, concentration for 50% growth inhibition: 16100 nM
Beside the measured number, compound 4's estimate is 1.1-fold (0.05 log units) above it; the range from low to high includes it.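

In this assay chloro in place of fluoro on the core of compound 3 gave a 1.1-fold higher number from compound 3 to compound 4 (0.03 log units; within the scatter) and so matched the step seen with the methyl-bearing core: the same change on two cores in this assay, a 1.3-fold higher number (0.10 log units; within the scatter) from compound 1 to compound 2 and a 1.1-fold higher number (0.03 log units; within the scatter) from compound 3 to compound 4, 1.2-fold (0.07 log units) apart, within the scatter of two such steps. Chloro in place of methyl, read here with the 2-chlorobenzyl group present, gave a 6.1-fold higher number from compound 2 to compound 4 (0.79 log units; beyond the scatter) and likewise matched its earlier step: the same change on two cores in this assay, a 7.2-fold higher number (0.85 log units; beyond the scatter) from compound 1 to compound 3 and a 6.1-fold higher number (0.79 log units; beyond the scatter) from compound 2 to compound 4, 1.2-fold (0.07 log units) apart, within the scatter of two such steps. Both changes therefore carried from one core to the other within these four compounds, but each rests on a single pair of steps in one assay, and this does not show that either would carry to other cores.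

The compounds shown leave open how a bromo, methoxy or nitrile group would read in place of the fluoro or chloro on the benzyl group. They also leave open how an amine or a carboxylic acid would read in place of the methyl or chloro on the other aromatic ring.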